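The source may hold more compounds than are shown below. What is called first, only, known or untested is meant among the compounds shown, and "the series" means these compounds.

Measured so far:
- compound 1, `O=C(COC(=O)/C=C/c1ccccc1)NCCC[Te]c1ccccc1`: 1000 nM
- compound 2, `COc1ccc(N(CC(=O)NCCC[Se]c2ccccc2)C(=O)/C=C/c2ccccc2)cc1`: >= 100000 nM
- compound 3, `COc1ccc(N(CC(=O)NCCC[Se]c2ccccc2)C(=O)C#Cc2ccccc2)cc1`: >= 100000 nM

Among the compounds with values here, in a functional assay on MCF7 cells (Homo sapiens) for cytotoxicity, read by MTT assay, with a stated time of 24 h (on this read-out lower numbers stand for stronger inhibition and higher numbers for weaker inhibition), compound 1 gives 1000 nM, the only number among the three values. For compound 2 the value >= 100000 nM is a limit of this assay, not a number. For compound 3 the value >= 100000 nM is likewise a limit. The step that the two limits leave unreadable from compound 2 to compound 3 therefore stays unreadable because of the limit of >= 100000 nM in this assay, at which 2 of the 3 values shown sit.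

Compound 4, `O=C(COC(=O)C#Cc1ccccc1)NCCC[Te]c1ccccc1`, has not yet been measured in this assay. It differs from compound 1 by 2-phenylethynyl in place of 2-phenylethenyl on a carbonyl carbon. Compound 3 differs from compound 2 by 2-phenylethynyl in place of 2-phenylethenyl on a carbonyl carbon. The two changes are the same kind of change rather than the same one: in compound 1 the carbonyl carbon sits on an oxygen next to a carbonyl group, in compound 2 on an amide-type nitrogen. The difference between the two cores is not broken down here.

Since the measured step gives no readable size, the expectation for compound 4 rests only on compound 1 and its value 1000 nM; the expected step is a 1.5-fold higher number from compound 1 to compound 4 (0.18 log units; within the scatter), within the usual scatter. The estimate for compound 4 is 1500 nM, with a range from 400 nM to 6000 nM.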

Compound 4, half-maximal inhibitory concentration in the MCF7 assay: 1000 nM
Beside the measured number, compound 4's estimate is 1.5-fold (0.18 log units) above it, and the stated range covers the measured number.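

In the MCF7 assay, putting 2-phenylethynyl in place of 2-phenylethenyl on the core of compound 1 gives no change at the digits printed from compound 1 to compound 4 (within the scatter), so on this core the swap leaves the cytotoxicity reading where it was. The same pair behaves very differently in a physicochemical assay for lipophilicity, read by HPLC, measured as octanol-water partition (a higher number here means a more lipophilic compound, a lower number a more polar compound), where compound 1 gives 3.01 and compound 4 gives 0.9. The swap makes the compound far less lipophilic while the cytotoxicity reading holds: the measured partition coefficient of compound 1, 3.01, and of compound 4, 0.9, a number 2.11 log units lower (beyond the scatter)

Compound 2 and compound 3, which carry the same swap on another core, each sit at a limit of the assay and not at a number, so their step cannot be read and this result cannot be said to carry over to that core or to fail there: the limit of >= 100000 nM in the MCF7 assay, at which 2 of the 4 values shown sit.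

The compounds shown leave open whether the swap would act alike on a core that keeps the tellurium but has the amide-type nitrogen of compound 2. They also leave open how both read-outs would respond if an amine or a carboxylic acid were added to the 2-phenylethynyl group.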